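The compounds below may be only part of what the source reports. "The series", "measured", "known", "first", "only" and "open" are said of these compounds alone.

- compound 1 `Cc1ccc(C(C)C)c(OCc2cn(-c3ccc(O)cc3)nn2)c1` gives 30500 nM in the assay below
- compound 2 `Cc1ccc(C(C)C)c(OCc2cn(-c3cccc(Cl)c3)nn2)c1` gives 45200 nM in the same assay

Within the data shown here, these are the only two numbers from a functional assay on MDA-MB-231 cells (Homo sapiens) for inhibition, read by MTT assay, with a stated time of 72 h (on this read-out higher numbers stand for weaker inhibition and lower numbers for stronger inhibition), so far. They lie within the scatter of each other, which leaves compound 1 with no distinct rank.

Compound 3 `Cc1cccc(-n2cc(COc3cc(C)ccc3C(C)C)nn2)c1` has not yet been measured. It carries 3-methylphenyl in place of 4-hydroxyphenyl on an aromatic nitrogen of the shared core.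

Among the measured compounds shown here, compound 2 is the only guide. Its measured change, a 1.5-fold higher number from compound 1 to compound 2 (0.17 log units; within the scatter) for 3-chlorophenyl in place of the same 4-hydroxyphenyl, stays small. No step beyond the scatter is therefore expected for compound 3 in this assay on this evidence.

The expected step is a 1.3-fold higher number from compound 1 to compound 3 (0.12 log units; within the scatter) and it remains within the scatter.

Compound 3 is estimated at 40000 nM with an expected range of 18000 nM to 85000 nM for repeat measurements.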

Compound 3, half-maximal inhibitory concentration: 31300 nM
Beside the measured number, compound 3's estimate is 1.3-fold (0.11 log units) above it; the measured number falls inside the stated range.
By their numbers in this assay, from the lowest: compounds 1, 3 and 2 (each within the scatter of the next).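

In this assay, the aryl group on the aromatic nitrogen now tolerates the loss of the 4-hydroxyphenyl group's hydrogen-bond donor and acceptor: 3-methylphenyl has neither, yet the exchange gives a 1.0-fold higher number from compound 1 to compound 3 (0.01 log units; within the scatter). The second comparison, methyl in place of chloro on an aromatic carbon, gives a 1.4-fold lower number from compound 2 to compound 3 (0.16 log units; within the scatter), so this exchange is not resolved either, and the three aryl groups shown cannot be told apart on this read-out. Nothing available here bears on why these groups give such similar numbers.

Going by these compounds, whether any group at this position can move the number beyond the scatter remains open. An amine or a carboxylic acid on the aromatic ring, or a longer chain in place of the methyl, could test this.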